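A few compounds are considered here, and "the series" means these few. Any claim that something is new, unique, unknown or untested is made for them only; others in the source may bear on it.

Three analogues share one core: compound 1 `CSCC[C@H](NC(=O)c1ccc(NCc2cncn2Cc2ccc(C#N)cc2)cc1-c1ccccc1)C(=O)O`, compound 2 `COC(=O)[C@H](CCSC)NC(=O)c1ccc(NCc2cncn2Cc2ccc(Cl)cc2)cc1-c1ccccc1` and compound 3 `CSCC[C@H](NC(=O)c1ccc(NCc2cncn2Cc2cccc(Cl)c2)cc1-c1ccccc1)C(=O)O`. In a functional assay on NIH3T3 cells (Mus musculus) (a higher number here means that more compound is needed for the effect, a lower number that less compound is needed), compound 1 reaches only the assay limit, > 10 uM. Compound 2 likewise shows only a limit in this assay, > 10 uM. Compound 3 too gives a limit in this assay, > 10 uM. The step that the two limits leave unreadable from compound 1 to compound 3 is therefore not readable, because of the limit of > 10 uM in this assay, at which 3 of the 3 values shown sit. Compound 4 `COC(=O)[C@H](CCSC)NC(=O)c1ccc(NCc2cncn2Cc2cccc(Cl)c2)cc1-c1ccccc1` differs from compound 3 by methyl in place of hydrogen on an oxygen next to a carbonyl group. Within the data shown here, no measured step covers this change, and compound 2, which carries the same methyl group, offers no readable number either. Compound 4 is thus expected to stay at the limit as well, estimated at 20 uM, with a range from 5 uM to 100 uM. The expected step is a step that the limit leaves unreadable from compound 3 to compound 4, no change beyond scatter.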

Compound 4, concentration for half-maximal effect: > 10 uM
Compound 4 gave a limit, no number; the forecaster's own chance of this, stated with the estimate: 85%; the middle value lies beyond the limit too.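

Among these compounds, no step to compound 4 can be read from compound 3 or compound 2, because all of them stand at the same limit: the limit of > 10 uM in this assay, at which 4 of the 4 values shown sit. The compounds shown leave open whether any change to the shared core gives a readable value in this assay at all.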